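Halogen swap on the indole ring of a diterpenoid ester

A few compounds are considered here, and "the series" means these few. Any claim that something is new, unique, unknown or untested is made for them only; others in the source may bear on it.

Three compounds of one shared core were measured in a functional assay on SW1573 cells (Homo sapiens) for inhibition, read by sulforhodamine B assay, with a stated time of 48 h; a higher number here means a weaker inhibitor of growth, a lower number a stronger inhibitor of growth. Compound 1, `COC(=O)[C@@]1(C)CCC=C2[C@@H]1CC[C@@H](C)[C@]2(C)Cc1c[nH]c2ccc(Br)cc12`, gives 12000 nM. Compound 2, `COC(=O)[C@@]1(C)CCC=C2[C@@H]1CC[C@@H](C)[C@]2(C)Cc1c[nH]c2ccc(Cl)cc12`, gives 11000 nM. Compound 3, `COC(=O)[C@@]1(C)CCC=C2[C@@H]1CC[C@@H](C)[C@]2(C)Cc1c(C)[nH]c2ccc(Br)cc12`, gives 14000 nM. Compound 1 and compound 2 differ by chloro in place of bromo on an aromatic carbon, and this change made a 1.1-fold lower number from compound 1 to compound 2 (0.04 log units; within the scatter). Compound 1 and compound 3 differ by methyl in place of hydrogen on an aromatic carbon, and this change made a 1.2-fold higher number from compound 1 to compound 3 (0.07 log units; within the scatter). Within the data shown here, compound 4, `COC(=O)[C@@]1(C)CCC=C2[C@@H]1CC[C@@H](C)[C@]2(C)Cc1c(C)[nH]c2ccc(Cl)cc12`, has not yet been measured in this assay; it differs from compound 3 by chloro in place of bromo on an aromatic carbon, which is the same change as the one from compound 1 to compound 2, at a place described in the same words. From compound 3 to compound 4, the step expected in this assay is a 1.1-fold lower number from compound 3 to compound 4 (0.03 log units; within the scatter), and this expectation rests on the fact that the same change gave a 1.1-fold lower number from compound 1 to compound 2 (0.04 log units; within the scatter). Compound 4 is therefore estimated to give 13000 nM in this assay, with a likely range from 6000 nM to 28000 nM.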

Compound 4, concentration for 50% growth inhibition: 14000 nM
The estimate for compound 4 lay 1.1-fold (0.03 log units) below the measured number, within the range that was stated.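

In this assay, chloro in place of bromo on an aromatic carbon gave no change at the digits printed from compound 3 to compound 4 (within the scatter), and the two readings of this swap, on cores with and without the added methyl, agree: the same change on two cores in this assay, a 1.1-fold lower number (0.04 log units; within the scatter) from compound 1 to compound 2 and no change at the digits printed (within the scatter) from compound 3 to compound 4, 1.1-fold (0.04 log units) apart, within the scatter of two such steps. Methyl in place of hydrogen on an aromatic carbon gave a 1.3-fold higher number from compound 2 to compound 4 (0.10 log units; within the scatter), and its two readings, with bromo and with chloro on the ring, agree as well: the same change on two cores in this assay, a 1.2-fold higher number (0.07 log units; within the scatter) from compound 1 to compound 3 and a 1.3-fold higher number (0.10 log units; within the scatter) from compound 2 to compound 4, 1.1-fold (0.04 log units) apart, within the scatter of two such steps. Across these four compounds, each change therefore carried from one core to the other without a gap beyond the scatter, but every step is itself within the scatter, so this shows only that two small steps stayed small and not that a step of real size would carry over in the same way.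

The compounds shown leave open whether fluoro, a nitrile or an amine in place of the halogen would move the number beyond the scatter. They also leave open what a longer chain in place of the added methyl, or a carboxylic acid in place of the methyl ester, would do.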